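The source may report more compounds than this note shows. Statements on the series, on what has been measured and on what is new or still open speak of the compounds shown alone.

Values so far in a functional assay on MGC-803 cells (Homo sapiens) for antiproliferative activity, read by MTT assay, with a stated time of 48 h (a higher number here means a weaker inhibitor, a lower number a stronger inhibitor), are as follows
- compound 1 `COc1ccc(CN(C(=O)CSC2=CN=NC2C)c2cc(OC)c(OC)c(OC)c2)cc1` gives 2960 nM
- compound 2 `COc1ccc(CN(C(=O)CSc2nc3ccc(OC)cc3s2)c2cc(OC)c(OC)c(OC)c2)cc1` gives 1270 nM
- compound 3 `COc1ccc(CN(C(=O)CCCSc2nc3ccccc3o2)c2cc(OC)c(OC)c(OC)c2)cc1` gives 1290 nM

Compound 3 (1290 nM) is not separated from compound 2 (1270 nM) by the measurement (a 1.0-fold higher number from compound 2 to compound 3 (0.01 log units; within the scatter)). Both stand apart from compound 1 (a 2.3-fold lower number from compound 1 to compound 3 (0.36 log units; beyond the scatter); a 2.3-fold lower number from compound 1 to compound 2 (0.37 log units; beyond the scatter)).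

Compound 4 `COc1ccc(CN(C(=O)CSc2nnnn2C)c2cc(OC)c(OC)c(OC)c2)cc1` places (1-methyl-1H-tetrazol-5-yl)sulfanyl in place of 2-((1,3-benzoxazol-2-yl)sulfanyl)ethyl on a saturated chain carbon bound to a carbonyl carbon.

For the measured compounds named here, the closest precedent is compound 1 (2960 nM), which also has a single five-membered ring on a sulfur, whereas compound 2 and compound 3 have two rings there. No tetrazole has been measured, so the range stays wide.

A modest step toward a weaker inhibitor is therefore expected in this assay, estimated as (a 2.2-fold higher number from compound 3 to compound 4 (0.34 log units; beyond the scatter)). The expected value for compound 4 is 2800 nM, with a range of 900 nM to 8000 nM.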

Compound 4, half-maximal inhibitory concentration: 2490 nM
For compound 4 the middle estimate is 1.1-fold (0.05 log units) above the measured one, within the range that was stated.
By their numbers in this assay, from the lowest: compounds 2, 3, 4 and 1 (each within the scatter of the next, the first and the last beyond it).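

In this assay, compound 4 is not separated from any earlier compound (a 1.9-fold higher number from compound 3 to compound 4 (0.29 log units; within the scatter); a 2.0-fold higher number from compound 2 to compound 4 (0.29 log units; within the scatter); a 1.2-fold lower number from compound 1 to compound 4 (0.08 log units; within the scatter)). A 1-methyl-1H-tetrazol-5-yl group on a sulfur therefore cannot be assigned to either the two-ring level of compound 2 and compound 3 or the level of compound 1, even though compound 1 stands apart from the other two. No evidence bearing on this result is available.

From the compounds shown here alone, it remains open how an amine or a carboxylic acid on the sulfur-bound ring would read, and whether any group at this position gives a step beyond the scatter from compound 4.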